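Urea to amide at the carbonyl, trifluoromethylphenyl kept

The compounds below may be only part of what the source reports. "The series", "measured", "known", "first", "only" and "open" are said of these compounds alone.

Compound 2 `COc1cc(Cl)cc(-c2nn(-c3cccc(NC(=O)Nc4cccc(C(F)(F)F)c4)c3)cc2-c2ccncc2)c1` stands lowest of the two numbers in a functional assay on KM12 cells (Homo sapiens) for inhibition, read by sulforhodamine B assay, with a stated time of 48 h, tested at 10 uM (a lower number here means a stronger effect, a higher number a weaker effect of the compound at the concentration tested), giving 9.81%; its nearest neighbour is compound 1 `COc1cc(Cl)cc(-c2nn(-c3cccc(NC(=O)c4ccc(Cl)c(Cl)c4)c3)cc2-c2ccncc2)c1`, which gives 62.3%. Compound 3 `COc1cc(Cl)cc(-c2nn(-c3cccc(NC(=O)c4cccc(C(F)(F)F)c4)c3)cc2-c2ccncc2)c1` differs from compound 2 by 3-(trifluoromethyl)phenyl in place of (3-(trifluoromethyl)phenyl)amino on a carbonyl carbon. For the measured compounds named here, the only measured step, a number 52.5 percentage points lower from compound 1 to compound 2 (beyond the scatter), changed both the carbonyl neighbour and the aryl at once, so no step isolates the present change; compound 3 shares the carbonyl-carbon arrangement of compound 1 and the aryl of compound 2. Compound 3 is therefore expected to land between them, with a rise of a number 30.2 percentage points higher from compound 2 to compound 3 (beyond the scatter), and is estimated at 40%, ranging from 10% to 75%.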

Compound 3, a percentage reported as activity, at one concentration (the size of the read-out at that concentration, not a potency): 43.7%
Beside the measured number, compound 3's estimate is 3.7 percentage points below it; measured number inside the range.
By their numbers in this assay, from the lowest: compound 2; then compound 3; then compound 1.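

In this assay removing only the amino link on the carbonyl carbon, with the 3-(trifluoromethyl)phenyl kept, gives a number 33.9 percentage points higher from compound 2 to compound 3 (beyond the scatter) and so shows that this link counts on its own. Exchanging 3,4-dichlorophenyl for 3-(trifluoromethyl)phenyl on the amide gives a number 18.6 percentage points lower from compound 1 to compound 3 (beyond the scatter) and shows that the aryl also counts, so the earlier combined step contains both changes. Nothing available here explains either step. Still open, from the compounds shown here alone, is how a thiourea or a carbamate at this carbonyl carbon would compare with the urea of compound 2.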